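This account rests on a few compounds, and the source may have more. Where it says the series, first, only, none or still open, it means among the compounds named here.

Of the compounds shown here, three have been measured so far in an ADME assay on Vero cells (Chlorocebus sabaeus) for cytotoxicity, read by CellTiter-Glo, with a stated time of 72 h; a lower number here means that less compound is tolerated, a higher number that more compound is tolerated. Compound 1 `[O-][n+]1nc(N[C@@H]2C[C@H]3CC[C@@H]2C3)[n+]([O-])c2ccccc21` gives 3.4 ug/mL. Compound 2 `[O-][n+]1nc(N[C@@H]2C[C@H]3CC[C@@H]2C3)[n+]([O-])c2ccc(Cl)cc21` gives 1.1 ug/mL. Compound 3 `CCNc1n[n+]([O-])c2cc(OC)ccc2[n+]1[O-]` gives 16 ug/mL, the highest of the three numbers.

Compound 4 `COc1ccc2c(c1)[n+]([O-])nc(N[C@@H]1C[C@H]3CC[C@@H]1C3)[n+]2[O-]` is still unmeasured and differs from compound 3 in one place: a group of 7 heavy atoms (7 carbon; 2 five-membered non-aromatic rings of carbon only) in place of a group of 2 heavy atoms (2 carbon; no ring), on a nitrogen on an aromatic ring. The small ethyl gives way to a much larger group with 2 five-membered non-aromatic rings of carbon only. Compounds 1 and 2 carry this same larger group, but they lack the methoxy group of compounds 3 and 4.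

For the measured compounds named here, no measured step isolates this swap. The only one available is a 3.1-fold lower number from compound 1 to compound 2 (0.49 log units; beyond the scatter), a modest step for a different change, chloro in place of hydrogen on an aromatic carbon. The better guide is the closest match to compound 4, which is compound 1 at 3.4 ug/mL, so a clearly lower number than that of compound 3 is expected in this assay. The expected step is a 4.0-fold lower number from compound 3 to compound 4 (0.60 log units; beyond the scatter). For compound 4 the estimated value is 4 ug/mL, within an expected range of 1.5 ug/mL to 10 ug/mL.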

Compound 4, half-maximal cytotoxic concentration: > 50 ug/mL
Compound 4: only a limit was reported (the forecaster's own chance of this, stated with the estimate: 3%); middle value at least 12-fold (1.09 log units) from the limit.
By their numbers in this assay, from the lowest: compound 2; then compound 1; then compound 3. At a limit, above all of these: compound 4.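

In this assay, compound 4 gives only a limit, > 50 ug/mL, and not a number. This shows that the larger group in place of ethyl, on a nitrogen on an aromatic ring, need not lower the number, since the change brings an at least 3.1-fold higher number from compound 3 to compound 4 (0.49 log units; beyond the scatter). With that larger group held constant, the group on the aromatic carbon makes a large difference: methoxy in place of hydrogen gives an at least 14-fold higher number from compound 1 to compound 4 (1.16 log units; beyond the scatter), and methoxy in place of chloro gives an at least 45-fold higher number from compound 2 to compound 4 (1.65 log units; beyond the scatter).

On these data alone, since compound 4 sits at a limit, the true size of all three steps stays unknown. The compounds shown also leave open whether a longer chain or an amine on this nitrogen, or a fluoro group in place of methoxy on the aromatic carbon, would keep the number this high.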